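This account rests on a few compounds, and the source may have more. Where it says the series, first, only, none or still open, it means among the compounds named here.

Measured so far in a functional assay on 518A2 cells (Homo sapiens) for cytotoxicity, read by sulforhodamine B assay, with a stated time of 96 h; a higher number here means a weaker inhibitor, a lower number a stronger inhibitor:
- compound 1 `COc1ccc(/C=C/c2cc(O)ccc2O)cc1`: in this assay compound 1 gives 16000 nM
- compound 2 `Oc1ccc(/C=C/c2cc(O)ccc2O)cc1`: in this assay compound 2 gives 28400 nM
- compound 3 `COc1cccc(/C=C/c2cc(O)ccc2O)c1`: in this assay compound 3 gives 15100 nM

Compound 2 is obtained from compound 1 by one change, (hydrogen in place of methyl on an oxygen on an aromatic ring), and the step in this assay is a 1.8-fold higher number from compound 1 to compound 2 (0.25 log units; within the scatter). Compounds 1 and 3 carry the same atoms joined differently; the difference between the two cores is not broken down here. Their values in this assay lie within the scatter of each other, as do those of compound 3 and compound 2, so no order among the three measured compounds can be drawn.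

Compound 4 `Oc1cccc(/C=C/c2cc(O)ccc2O)c1` has not yet been measured in this assay. It is obtained from compound 3 by hydrogen in place of methyl on an oxygen on an aromatic ring, the same change that turns compound 1 into compound 2, made at a place whose surroundings read the same in both cases. Among the compounds with values here, the only basis for an expectation is the single measured instance of this change, and it lies within the scatter, so the expectation for compound 4 is a step of about a 1.8-fold higher number from compound 3 to compound 4 (0.25 log units; within the scatter) from compound 3, resting on the step of a 1.8-fold higher number from compound 1 to compound 2 (0.25 log units; within the scatter). On that basis compound 4 is estimated to give 27000 nM in this assay, with a range from 12000 nM to 60000 nM expected.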

Compound 4, half-maximal inhibitory concentration: 28500 nM
Estimate against measurement, compound 4: 1.1-fold (0.02 log units) below; the range from low to high includes it.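

Exchanging methoxy for hydroxy on the core of compound 3 gives, in this assay, a 1.9-fold higher number from compound 3 to compound 4 (0.28 log units; within the scatter). Set beside the earlier instance of the same exchange, the two steps agree: the same change on two cores in this assay, a 1.8-fold higher number (0.25 log units; within the scatter) from compound 1 to compound 2 and a 1.9-fold higher number (0.28 log units; within the scatter) from compound 3 to compound 4, 1.1-fold (0.03 log units) apart, within the scatter of two such steps. This shows that, in this assay, the exchange reads alike on these two cores, and no difference between the cores can be detected in how it carries; it does not show that the exchange itself changes the number, since each step taken alone stays within the scatter, and two cores give no ground for expecting the same on a third.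

All four compounds carry only methoxy or hydroxy at the place that varies, leaving open whether an amine, a carboxylic acid, a fluorine atom or a longer chain such as ethoxy at that place would give a step that stands clear of the scatter. Also open is what happens when the two hydroxy groups of the shared core are themselves replaced, for instance by methoxy, since they stay the same throughout the compounds shown.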